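Adding a Selenium-Bearing Group: What to Expect

The source may report more compounds than this note shows. Statements on the series, on what has been measured and on what is new or still open speak of the compounds shown alone.

Compound 3 `CSc1nc(NCc2ccccc2)c2ccccc2n1` is compared in a functional assay on HT-29 cells (Homo sapiens) for cytotoxicity, read by MTT assay, with a stated time of 72 h (on this read-out higher numbers stand for weaker inhibition of growth and lower numbers for stronger inhibition of growth), with two relatives. Compound 3 gives 36500 nM, the second highest of the three numbers. Its nearest neighbour is compound 1 `COc1ccc(CNc2nc(SC)nc3ccccc23)cc1`, which gives 70200 nM; the step of a 1.9-fold lower number from compound 1 to compound 3 (0.28 log units; within the scatter) lies within the scatter. Compound 2 `CCCCCSc1nc(NCc2ccc([Se]C)cc2)c2ccccc2n1`, which gives 14400 nM, differs from compound 3 in two places, so its lower number cannot be tied to a single change. The unmeasured compound 4 `CSc1nc(NCc2ccc([Se]C)cc2)c2ccccc2n1` differs from compound 3 by a group of 2 heavy atoms (1 carbon, 1 selenium; no ring) in place of a hydrogen atom, on an aromatic carbon. For the measured compounds named here, no measured step isolates this change; the only single step, from compound 1 to compound 3, concerns a different group and stays within the scatter. Compound 4 is therefore expected to shift only modestly, as a 1.8-fold lower number from compound 3 to compound 4 (0.26 log units; within the scatter), giving an estimated 20000 nM with a range from 8000 nM to 50000 nM.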

Compound 4, concentration for 50% growth inhibition: > 100000 nM
Compound 4: only a limit was reported; the forecaster's own chance of this, stated with the estimate: 5%; at least 5.0-fold (0.69 log units) between middle value and limit.
By their numbers in this assay, from the lowest: compound 2; then compounds 3 and 1 (each within the scatter of the next). At a limit, above all of these: compound 4.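

Compound 4 gives only a limit, not a number: the limit of > 100000 nM in this assay, at which 1 of the 4 values shown sits. Even so, putting the selenium-bearing group in place of hydrogen on this aromatic carbon weakens growth inhibition at least modestly, with an at least 2.7-fold higher number from compound 3 to compound 4 (0.43 log units; beyond the scatter). The chain on sulfur also counts once this group is present, with an at least 6.9-fold higher number from compound 2 to compound 4 (0.84 log units; beyond the scatter), where hydrogen stands in place of butyl. One step cannot be read, as its floor lies within the scatter (an at least 1.4-fold higher number from compound 1 to compound 4 (0.15 log units; that floor lies within the scatter)). Going by these compounds, whether an amine or a carboxylic acid in this same place would also weaken growth inhibition remains open.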